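A few compounds are considered here, and "the series" means these few. Any claim that something is new, unique, unknown or untested is made for them only; others in the source may bear on it.

Compound 1 `CCN(Cc1ccc2nc(C)[nH]c(=O)c2c1)c1ccc(C(=O)N[C@@H](CCC(=O)O)C(=O)O)c(F)c1`: 45 nM
Compound 2 `C=CCN(Cc1ccc2nc(C)[nH]c(=O)c2c1)c1ccc(C(=O)N[C@@H](CCC(=O)O)C(=O)O)c(F)c1`: 76 nM
Compound 3 `Cc1nc2ccc(CN(C)c3ccc(C(=O)N[C@@H](CCC(=O)O)C(=O)O)c(F)c3)cc2c(=O)[nH]1`: 120 nM

All three were measured in an assay on isolated protein for inhibition of Thymidylate synthase (Mus musculus); on this read-out lower numbers stand for stronger inhibition and higher numbers for weaker inhibition. Compound 3 stands at the highest of the three numbers. Its gap to compound 2 is within the scatter, a 1.6-fold higher number from compound 2 to compound 3 (0.20 log units; within the scatter), whereas the gap to compound 1 is beyond it, a 2.7-fold higher number from compound 1 to compound 3 (0.43 log units; beyond the scatter), a modest step.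

Compound 4 `C#CCN(Cc1ccc2nc(C)[nH]c(=O)c2c1)c1ccc(C(=O)N[C@@H](CCC(=O)O)C(=O)O)c(F)c1` differs from compound 3 by ethynyl in place of hydrogen on a saturated chain carbon bound to a nitrogen on an aromatic ring. Within the data shown here, two measured steps bear on this change, both at the same carbon: a 2.7-fold higher number from compound 1 to compound 3 (0.43 log units; beyond the scatter) and a 1.6-fold higher number from compound 2 to compound 3 (0.20 log units; within the scatter). Read in reverse, both say that replacing the hydrogen with a larger group lowers the number in this assay, clearly for compound 1 and only within the scatter for compound 2. Ethynyl is a two-carbon group like the vinyl of compound 2 and the methyl of compound 1 is the nearest comparison, so a lower number than compound 3 is expected, of a size comparable to the step seen for compound 1. The estimated step is a 2.7-fold lower number from compound 3 to compound 4 (0.43 log units; beyond the scatter), a lower number on this read-out. Compound 4 is therefore expected to give 45 nM. For compound 4 the range is estimated from 18 nM to 120 nM.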

Compound 4, half-maximal inhibitory concentration: 20 nM
Beside the measured number, compound 4's estimate is 2.3-fold (0.35 log units) above it; the measured number falls inside the stated range.
By their numbers in this assay, from the lowest: compound 4; then compounds 1, 2 and 3 (each within the scatter of the next, the first and the last beyond it).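

In this assay this saturated chain carbon bound to a nitrogen on an aromatic ring proves sensitive to the kind of group it carries, and not only to whether a group is present: ethynyl in place of hydrogen gives a 6.0-fold lower number from compound 3 to compound 4 (0.78 log units; beyond the scatter) and so a larger step than either earlier step at this carbon. The change also separates ethynyl from the other two groups, with a 3.8-fold lower number from compound 2 to compound 4 (0.58 log units; beyond the scatter) against vinyl and a 2.3-fold lower number from compound 1 to compound 4 (0.35 log units; beyond the scatter) against methyl, which makes compound 4 the strongest inhibitor of the four, although methyl and vinyl had stayed within the scatter of each other. Nothing measured here accounts for why the triple bond outperforms the double bond at this carbon.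

The compounds shown leave open whether a nitrile or a longer chain ending in a triple bond would hold or extend this gain, and how a hydroxyl group or an amine would fare at the same carbon. They also leave open whether ethynyl would give a similar step if another group, such as chlorine, replaced the fluorine on the shared core.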